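A few compounds are considered here, and "the series" means these few. Any claim that something is new, unique, unknown or untested is made for them only; others in the source may bear on it.

Measured so far:
- Compound 1 `O=[N+]([O-])c1cc(-c2nnc(SCc3ccccc3)n2Cc2ccccc2)cc([N+](=O)[O-])c1`: > 30000 nM
- Compound 2 `O=[N+]([O-])c1cc(-c2nnc(SCc3ccc(Br)cc3)n2Cc2ccccc2)cc([N+](=O)[O-])c1`: > 30000 nM

In an ADME assay on A-431 cells (Homo sapiens) for cytotoxicity, with a stated time of 48 h (on this read-out lower numbers stand for stronger inhibition and higher numbers for weaker inhibition), compound 1 gives > 30000 nM, which is a limit of the assay and not a number. Compound 2 gives > 30000 nM, also a limit. The data therefore hold no exact value, only (the limit of > 30000 nM in this assay, at which 2 of the 2 values shown sit).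

Compound 3 `O=[N+]([O-])c1cc(-c2nnc(SCc3ccccc3)n2Cc2ccccc2)cc(C(F)(F)F)c1` keeps the core of compound 1 but carries trifluoromethyl in place of nitro on an aromatic carbon.

Within the data shown here, the only measured step, a step that the two limits leave unreadable from compound 1 to compound 2, is a different change, bromo in place of hydrogen on an aromatic carbon, and it offers no size to carry over. The expectation rests on compound 1 at > 30000 nM, again a limit, so no step beyond the usual scatter is expected in this assay, in either direction. The expected outcome is a number no higher from compound 1 to compound 3 (the limit leaves the size open). The estimate for compound 3 is 30000 nM, with an expected range of 12000 nM to 60000 nM.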

Compound 3, half-maximal inhibitory concentration: 10100 nM
Compound 3: middle estimate off by 3.0-fold (0.47 log units), on the high side; the whole stated range lies above it.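

Exchanging one nitro group for trifluoromethyl, on the aromatic carbon meta to a nitro group, gives an at least 2.9-fold lower number from compound 1 to compound 3 (0.47 log units; beyond the scatter) in this assay, so the number does respond to a change of group at this position. The bromo change cannot be read, as both of its compounds sit at a limit, which leaves this as the only change shown with a visible effect. Compound 3 is also the only compound here with an exact value, while the others stand at a limit: the limit of > 30000 nM in this assay, at which 2 of the 3 values shown sit.

The compounds shown leave open whether the gain comes from losing nitro or from gaining trifluoromethyl, and whether another group at this position, such as an amine or a carboxylic acid, would move the number further. They also leave open what exchanging the second nitro group would do.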